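Halogen Swap on the Anilino Ring: Chloro to Bromo

The compounds below may be only part of what the source reports. "The series", "measured", "known", "first", "only" and "open" are said of these compounds alone.

Compound 1 `C=CC(=O)Nc1cccc(NC(=O)CSc2nc(Nc3ccccc3F)c3ccccc3n2)c1`: 26100 nM
Compound 2 `C=CC(=O)Nc1cccc(NC(=O)CSc2nc(Nc3ccccc3Cl)c3ccccc3n2)c1`: 20700 nM

In a functional assay on MGC-803 cells (Homo sapiens) for inhibition, read by MTT assay, with a stated time of 72 h (on this read-out higher numbers stand for weaker inhibition and lower numbers for stronger inhibition), compound 2 gives 20700 nM, the lower of the two numbers shown, while compound 1 gives 26100 nM; the single measured step, a 1.3-fold lower number from compound 1 to compound 2 (0.10 log units; within the scatter), lies within the scatter, so the two compounds cannot be told apart on this read-out. Compound 3 `C=CC(=O)Nc1cccc(NC(=O)CSc2nc(Nc3ccccc3Br)c3ccccc3n2)c1` differs from compound 2 by bromo in place of chloro on an aromatic carbon. Going by the values given here, the one measured step that bears on this change is the earlier halogen exchange at the same kind of site, fluoro to chloro, which gave a movement no larger than the scatter. On that basis no step beyond the scatter is expected from compound 2 to compound 3, at most a slight drift toward a lower number. Compound 3 is therefore estimated at 17000 nM, with a range from 8000 nM to 40000 nM. The expected step, a 1.2-fold lower number from compound 2 to compound 3 (0.09 log units; within the scatter), is accordingly small.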

Compound 3, half-maximal inhibitory concentration: 12800 nM
Compound 3: the middle estimate sits 1.3-fold (0.12 log units) above what was measured, and the stated range covers the measured number.
By their numbers in this assay, from the lowest: compounds 3, 2 and 1 (each within the scatter of the next, the first and the last beyond it).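

In this assay, the exchange of chloro for bromo gives a 1.6-fold lower number from compound 2 to compound 3 (0.21 log units; within the scatter), so this change alone does not separate the two compounds. Across the three halogens at this aromatic carbon, however, only the two ends can be told apart: bromo in place of fluoro gives a 2.0-fold lower number from compound 1 to compound 3 (0.31 log units; beyond the scatter), the first step at this position to lie beyond the scatter, and a modest one. No measured evidence bears on why the number differs between these halogens.

The compounds shown carry only fluoro, chloro and bromo at this place, so it remains open whether iodo would extend the difference. Going by these compounds, it also remains open how a methyl, a methoxy or an amine at the same aromatic carbon would compare with bromo.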